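Phenoxy to Benzyloxy on an Acid and an Ester Core

The source may report more compounds than this note shows. Statements on the series, on what has been measured and on what is new or still open speak of the compounds shown alone.

Compound 1 `CC(C)N(Cc1cccc(OCCCCCC(=O)O)c1)C(=O)c1ccc(-c2cccc(Oc3ccccc3)c2)cc1` was tested in an ADME assay on Raji cells (Homo sapiens) for cytotoxicity, read by CellTiter-Glo and resazurin assay, with a stated time of 72 h; on this read-out lower numbers stand for an effect already at smaller amounts and higher numbers for an effect only at larger amounts of compound. In this assay compound 1 gives only a limit, > 18700 nM. Compound 2 `CC(C)N(Cc1cccc(OCCCCCC(=O)O)c1)C(=O)c1ccc(-c2cccc(OCc3ccccc3)c2)cc1` differs from compound 1 by benzyl in place of phenyl on an oxygen on an aromatic ring. In this assay compound 2 also reaches only a limit, > 26000 nM. That step, a step that the two limits leave unreadable from compound 1 to compound 2, stays unreadable because the limit of > 18700 nM in this assay, at which 1 of the 3 values shown sits, and the limit of > 26000 nM in this assay, at which 1 of the 3 values shown sits, both sit at limits. The two cores differ by ethyl in place of hydrogen on an oxygen next to a carbonyl group, and the step that the two limits leave unreadable from compound 1 to compound 3 is likewise unreadable because of the limit of > 19600 nM in this assay, at which 1 of the 3 values shown sits. Compound 3 `CCOC(=O)CCCCCOc1cccc(CN(C(=O)c2ccc(-c3cccc(Oc4ccccc4)c3)cc2)C(C)C)c1` gives only a limit in this assay, > 19600 nM. Compound 4 `CCOC(=O)CCCCCOc1cccc(CN(C(=O)c2ccc(-c3cccc(OCc4ccccc4)c3)cc2)C(C)C)c1` is not yet measured; it differs from compound 3 by benzyl in place of phenyl on an oxygen on an aromatic ring, the same change as from compound 1 to compound 2. With compound 3 sitting at the limit of > 19600 nM in this assay, at which 1 of the 3 values shown sits, compound 4 is expected to give 30000 nM in this assay, between 15000 nM and 100000 nM, an estimated step that the limit leaves unreadable from compound 3 to compound 4 that is expected to remain unreadable as well.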

Compound 4, half-maximal effective concentration: > 26000 nM
Compound 4: only a limit was reported (the forecaster's own chance of this, stated with the estimate: 85%); the middle value is on the limit's open side.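

Compound 4 also gives only a limit in this assay, so neither its step from compound 3 nor its step from compound 2 can be read. The compounds shown leave open whether either change alters the read-out at all, since all four stand at limits.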